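Dimethylpiperidine in Place of Hydroxypiperidine: Cytotoxicity Outlook

The source may hold more compounds than are shown below. What is called first, only, known or untested is meant among the compounds shown, and "the series" means these compounds.

compound 1 `Cc1cc(C)c(S(=O)(=O)N2CCC(N3CCC(O)CC3)CC2)c(C)c1` — > 5000 nM
compound 2 `C#CCCC(=O)CC1CCN(C2CCN(S(=O)(=O)c3c(C)cc(C)cc3C)CC2)CC1` — > 5000 nM
compound 3 `CC1CCN(C2CCN(S(=O)(=O)c3ccc([N+](=O)[O-])c(C(F)(F)F)c3)CC2)CC1` — > 5000 nM

In an ADME assay on HCT-116 cells (Homo sapiens) for cytotoxicity, read by CellTiter-Glo, with a stated time of 72 h (a higher number here means a weaker inhibitor, a lower number a stronger inhibitor), compound 1 gives only a limit, > 5000 nM. Compound 2 likewise gives a limit, > 5000 nM. Compound 3 also stops at a limit, > 5000 nM. Going by the values given here, compound 1 therefore stands on a limit rather than a number, and the one measured step that touches it, a step that the two limits leave unreadable from compound 1 to compound 2, cannot be read in size. The unmeasured compound 4 `Cc1cc(C)c(S(=O)(=O)N2CCC(N3CC(C)CC(C)C3)CC2)c(C)c1` differs from compound 1 by 3,5-dimethylpiperidin-1-yl in place of 4-hydroxypiperidin-1-yl on a saturated ring carbon. Among the compounds with values here, no measured step speaks to this change, and because the limit of > 5000 nM in this assay, at which 3 of the 3 values shown sit, every value shown is a limit, no step size in this assay can be expected in either direction beyond a guess. Compound 4 is expected to give 8000 nM, with a range from 3000 nM to 30000 nM. The step so estimated is a step that the limit leaves unreadable from compound 1 to compound 4.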

Compound 4, half-maximal inhibitory concentration: > 5000 nM
Compound 4: only a limit was reported (the forecaster's own chance of this, stated with the estimate: 85%); the middle value does not contradict the limit.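

The step from compound 1 to compound 4 cannot be read, since both values are limits: the limit of > 5000 nM in this assay, at which 4 of the 4 values shown sit.

The compounds shown leave open whether 3,5-dimethylpiperidin-1-yl in place of 4-hydroxypiperidin-1-yl shifts the read-out at all, and what actual number any of the four compounds would give.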